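The source may hold more compounds than are shown below. What is called first, only, known or untested is meant among the compounds shown, and "the series" means these compounds.

Compound 1 `COc1ccc(/C=N/C(C#N)=C(/C#N)NC(=O)NS(=O)(=O)c2ccc(C)cc2)cc1` and compound 2 `COc1cc(/C=N/C(C#N)=C(/C#N)NC(=O)NS(=O)(=O)c2ccc(C)cc2)cc(OC)c1` share one core, while compound 3 `COc1ccc(/C=N/c2c(C#N)nc(=O)[nH]c2NS(=O)(=O)c2ccc(C)cc2)cc1` and compound 4 `COc1cc(/C=N/c2c(C#N)nc(=O)[nH]c2NS(=O)(=O)c2ccc(C)cc2)cc(OC)c1` share another. Compound 1 and compound 3 are built from the same atoms joined differently, and the difference between the two cores is not broken down here. In a functional assay on Ehrlich cells (Mus musculus) for cytotoxicity, with a stated time of 48 h (on this read-out higher numbers stand for weaker inhibition of growth and lower numbers for stronger inhibition of growth), compound 1 gives 10000 nM, compound 2 gives 25000 nM, and compound 3 gives 17000 nM. Compound 2 differs from compound 1 by 3,5-dimethoxyphenyl in place of 4-methoxyphenyl on a carbon with a double bond to nitrogen, and that change made a 2.5-fold higher number from compound 1 to compound 2 (0.40 log units; beyond the scatter). Compound 4 differs from compound 3 by the same change, (3,5-dimethoxyphenyl in place of 4-methoxyphenyl on a carbon with a double bond to nitrogen). Among the compounds with values here, the step from compound 3 to compound 4 is expected to be a 2.4-fold higher number from compound 3 to compound 4 (0.37 log units; beyond the scatter) because the one earlier example of this change gave a 2.5-fold higher number from compound 1 to compound 2 (0.40 log units; beyond the scatter) on a different core, and a single example is a thin basis. Compound 4 is therefore expected to give 40000 nM, most likely between 15000 nM and 100000 nM.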

Compound 4, concentration for 50% growth inhibition: 19000 nM
For compound 4 the middle estimate is 2.1-fold (0.32 log units) above the measured one, and the stated range covers the measured number.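

On the core of compound 3, putting 3,5-dimethoxyphenyl in place of 4-methoxyphenyl in this assay gave a 1.1-fold higher number from compound 3 to compound 4 (0.05 log units; within the scatter), so the swap shows no clear effect on this core. Set beside the earlier step, the two results do not differ by more than repeated measurements can: the same change on two cores in this assay, a 2.5-fold higher number (0.40 log units; beyond the scatter) from compound 1 to compound 2 and a 1.1-fold higher number (0.05 log units; within the scatter) from compound 3 to compound 4, 2.2-fold (0.35 log units) apart, within the scatter of two such steps. Within the data shown here, this shows no conflict between the two cores, but it does not show that the change carries over, since only one of the two steps lies beyond the scatter and two examples are few.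

The compounds shown leave open how this assay would respond to other groups on the aromatic ring, such as an amine or a carboxylic acid in place of the methoxy groups.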